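The compounds below may be only part of what the source reports. "The series", "measured", "known", "first", "only" and "open" are said of these compounds alone.

Compound 1 `CCOC(=O)c1cc(-c2cccc(OCc3cccc([N+](=O)[O-])c3)c2)on1` is the starting point. In an ADME assay on Vero cells (Chlorocebus sabaeus) for cytotoxicity, with a stated time of 72 h (a lower number here means a stronger inhibitor, a higher number a weaker inhibitor), compound 1 gives > 128000 nM, which is a limit of the assay rather than a number. Compound 2 `CCOC(=O)c1cc(-c2cccc(OCc3ccc(F)cc3)c2)on1` has "not determined" (no result reported) in this assay. Compound 3 `CCOC(=O)c1cc(-c2cccc(OCc3ccc(F)cc3F)c2)on1` gives > 128000 nM in this assay, again a limit. The step that the two limits leave unreadable from compound 1 to compound 3 cannot be read in size because of the limit of > 128000 nM in this assay, at which 2 of the 3 values shown sit. Compound 4 `CCOC(=O)c1cc(-c2cccc(OCc3ccc(F)c(F)c3F)c2)on1` differs from compound 1 as follows: 2,3,4-trifluorophenyl in place of 3-nitrophenyl on a saturated chain carbon bound to an oxygen on an aromatic ring. For the measured compounds named here, the only measured step that bears on this change is the one between compound 1 and compound 3, and its size is hidden by the limits, so no direction beyond the usual scatter can be read for this assay. Compound 4 is expected to show a step that the limit leaves unreadable from compound 1 to compound 4, that is an estimated 200000 nM with a range from 100000 nM to 500000 nM.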

Compound 4, half-maximal inhibitory concentration: > 128000 nM
Compound 4: a limit, no number (the forecaster's own chance of this, stated with the estimate: 85%); the middle value is on the limit's open side.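

No step can be read between compound 1, compound 3 and compound 4 in this assay, because all three stop at the same limit: the limit of > 128000 nM in this assay, at which 3 of the 4 values shown sit.

The compounds shown leave open whether 2,3,4-trifluorophenyl in place of 3-nitrophenyl changes the result at all.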